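Moving one chlorine on a dichlorophenyl group

A few compounds are considered here, and "the series" means these few. Any claim that something is new, unique, unknown or untested is made for them only; others in the source may bear on it.

Of the compounds shown here, three sharing one core have been measured in a functional assay on MCF cells (Homo sapiens) for antiproliferative activity, with a stated time of 72 h; on this read-out lower numbers stand for stronger inhibition and higher numbers for weaker inhibition. There, compound 1 `OC[C@H]1O[C@@H](n2cnc3c(NCc4ccc(F)cc4)ncnc32)[C@H](O)[C@@H]1O` gives 21000 nM and compound 3 `OC[C@H]1O[C@@H](n2cnc3c(NCc4ccc(Cl)cc4Cl)ncnc32)[C@H](O)[C@@H]1O` gives 127000 nM, the higher of the two actual numbers. Compound 2 `OC[C@H]1O[C@@H](n2cnc3c(NCc4ccccc4Br)ncnc32)[C@H](O)[C@@H]1O` gives > 166000 nM, which is a limit of the assay and not a number.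

The next candidate is compound 4 `OC[C@H]1O[C@@H](n2cnc3c(NCc4ccc(Cl)c(Cl)c4)ncnc32)[C@H](O)[C@@H]1O`, where 3,4-dichlorophenyl replaces 2,4-dichlorophenyl on a saturated chain carbon bound to a nitrogen on an aromatic ring: 3,4-dichlorophenyl in place of 2,4-dichlorophenyl on a saturated chain carbon bound to a nitrogen on an aromatic ring. The atoms stay the same but are joined differently.

Within the data shown here, no measured step makes this exact change, so the nearest evidence is indirect. The step of a 6.0-fold higher number from compound 1 to compound 3 (0.78 log units; beyond the scatter) and the step of an at least 7.9-fold higher number from compound 1 to compound 2 (0.89 log units; beyond the scatter) both lead away from the 4-fluorophenyl group to weaker inhibition. The step of an at least 1.3-fold lower number from compound 2 to compound 3 (0.11 log units; that floor lies within the scatter) separates the two weaker compounds by no more than the scatter. The names 2-bromophenyl and 2,4-dichlorophenyl share a 2, which 4-fluorophenyl and 3,4-dichlorophenyl lack, although three compounds make a thin pattern. Compound 4 therefore is expected to recover part of the gap towards compound 1 at 21000 nM, not all of it.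

The expected change is a 2.5-fold lower number from compound 3 to compound 4 (0.40 log units; beyond the scatter). For compound 4 the estimated value is 50000 nM, with an expected range of 15000 nM to 160000 nM.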

Compound 4, half-maximal inhibitory concentration: 88800 nM
The estimate for compound 4 lay 1.8-fold (0.25 log units) below the measured number, within the range that was stated.
By their numbers in this assay, from the lowest: compound 1; then compounds 4 and 3 (each within the scatter of the next). At a limit, above all of these: compound 2.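

Moving one chlorine, from 2,4-dichlorophenyl to 3,4-dichlorophenyl, makes no difference that can be told apart in this assay: a 1.4-fold lower number from compound 3 to compound 4 (0.16 log units; within the scatter). The 4-fluorophenyl compound stays clearly separate from the new one, a 4.2-fold higher number from compound 1 to compound 4 (0.63 log units; beyond the scatter), so the hint that a group carrying a 2 in its name marks the weaker compounds does not hold up, and compound 4 goes against it by lacking the 2 yet still sitting well away from compound 1. The remaining comparison, an at least 1.8-fold lower number from compound 2 to compound 4 (0.27 log units; that floor lies within the scatter), rests on a limit of the assay and not a number, and it fixes no order: the limit of > 166000 nM in this assay, at which 1 of the 4 values shown sits.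

The compounds shown leave open whether the gap to compound 1 follows the second chlorine or the change from fluorine to chlorine, a question that a single 4-chlorophenyl group or a plain phenyl group would bear on directly. They also say nothing about a carboxylic acid or an amine on this ring, or about a longer chain joining the ring to the nitrogen.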